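Chloro for fluoro on a potent growth inhibitor

A few compounds are considered here, and "the series" means these few. Any claim that something is new, unique, unknown or untested is made for them only; others in the source may bear on it.

Compound 1 `Cc1ccnc2nc(-c3cccc(Cl)c3)cc(O)c12` gives 15.9 nM
Compound 2 `Cc1cc(C)c2c(O)cc(-c3cccc(F)c3)nc2n1` gives < 10 nM (a limit, not a number)

Both compounds were tested in a functional assay on HCT-116 cells (Homo sapiens) for antiproliferative activity (a higher number here means a weaker inhibitor of growth, a lower number a stronger inhibitor of growth), where small numbers are the ones of interest. Compound 1 has a true measured value of 15.9 nM in this test. For compound 2 the test returns < 10 nM as a limit and not as an exact number. This leaves compound 2 without a precise position, and the data so far include the limit of < 10 nM in this assay, at which 1 of the 2 values shown sits, as a caution for any new result.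

The change chloro in place of fluoro on an aromatic carbon turns compound 2 into compound 3 `Cc1cc(C)c2c(O)cc(-c3cccc(Cl)c3)nc2n1` and amounts to chloro in place of fluoro on an aromatic carbon. Going by the values given here, no measured pair of compounds shows this swap on its own, so there is no direct precedent for its size. In this assay the estimated change is a step that the limit leaves unreadable from compound 2 to compound 3 and it is expected to stay within the usual scatter, with no firm direction. Compound 3 may well return only a limit too. For compound 3 the expected value is 8 nM (range 3 nM to 20 nM)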

Compound 3, concentration for 50% growth inhibition: 170 nM
For compound 3 the middle estimate is 21-fold (1.33 log units) below the measured one; the measured number lies above the stated range.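

A small swap at this place has a large effect. In this assay, putting chloro in place of fluoro on an aromatic carbon of the carbon-only ring, meta to a large group, gives an at least 17-fold higher number from compound 2 to compound 3 (1.23 log units; beyond the scatter), so this position clearly distinguishes between these two halogens when the added methyl is present. The added methyl matters too: with chloro held constant, methyl in place of hydrogen on an aromatic carbon gives an 11-fold higher number from compound 1 to compound 3 (1.03 log units; beyond the scatter), which is a clear loss of growth inhibition from a single extra carbon. Compound 2 has only a limit and not a number, so the first of these steps has no exact size: the limit of < 10 nM in this assay, at which 1 of the 3 values shown sits.

The compounds shown do not explain why either step is so large, and they do not show whether the added methyl would cost as much with fluoro on the ring as it does with chloro. Only fluoro and chloro appear at this place, so how bromo, methoxy or a nitrile would fare there remains an open question.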